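From 3,4-dimethoxyphenyl to 3-fluoro-4-hydroxyphenyl in compound 4

The source may hold more compounds than are shown below. What is called first, only, known or untested is meant among the compounds shown, and "the series" means these compounds.

compound 1 `COc1ccc(OC)c(/C=C/C(=O)/C=C(O)/C=C/c2cc(OC)ccc2OC)c1` - 14700 nM
compound 2 `COc1ccc(OC)c(/C=C/C(=O)C(=Cc2ccc(O)c(OC)c2)C(=O)/C=C/c2cc(OC)ccc2OC)c1` - 340 nM
compound 3 `COc1ccc(OC)c(/C=C/C(=O)C(=Cc2ccc(OC)c(OC)c2)C(=O)/C=C/c2cc(OC)ccc2OC)c1` - 550 nM

All three values come from a functional assay on CNE-2 cells (Homo sapiens) for antiproliferative activity, read by sulforhodamine B assay, with a stated time of 48 h; on this read-out higher numbers stand for weaker inhibition and lower numbers for stronger inhibition. Compound 3 gives 550 nM, and compound 1 gives 14700 nM, so compound 3 is the far stronger inhibitor of the two. Its nearest neighbour is compound 2, and the gap between them is a 1.6-fold higher number from compound 2 to compound 3 (0.21 log units; within the scatter).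

The next compound, compound 4 `COc1ccc(OC)c(/C=C/C(=O)C(=Cc2ccc(O)c(F)c2)C(=O)/C=C/c2cc(OC)ccc2OC)c1`, has not yet been measured. In it, 3-fluoro-4-hydroxyphenyl takes the place of 3,4-dimethoxyphenyl on a double-bonded chain carbon bound to a double-bonded chain carbon (3-fluoro-4-hydroxyphenyl in place of 3,4-dimethoxyphenyl on a double-bonded chain carbon bound to a double-bonded chain carbon).

For the measured compounds named here, only one measured step bears on this change. It places a methyl on an aromatic ring oxygen in place of hydrogen, the reverse of one part of the new swap, and its size is a 1.6-fold higher number from compound 2 to compound 3 (0.21 log units; within the scatter). Going by the values given here, no measured compound carries fluorine, so that part of the change remains untested. A small shift toward a lower number is therefore expected, with no move clearly beyond the scatter. The expected step is a 1.4-fold lower number from compound 3 to compound 4 (0.14 log units; within the scatter). For compound 4 the estimated value is 400 nM, with an expected range from 150 nM to 1100 nM.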

Compound 4, half-maximal inhibitory concentration: 380 nM
Beside the measured number, compound 4's estimate is 1.1-fold (0.02 log units) above it; measured number inside the range.
By their numbers in this assay, from the lowest: compounds 2, 4 and 3 (each within the scatter of the next); then compound 1.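

In this assay, placing 3-fluoro-4-hydroxyphenyl where 3,4-dimethoxyphenyl stood on a double-bonded chain carbon bound to a double-bonded chain carbon gives a 1.4-fold lower number from compound 3 to compound 4 (0.16 log units; within the scatter) and so leaves the number where it was, within the scatter. For the compounds shown here, this is the first sign that this position accepts a ring carrying fluorine, and that the two methoxy groups of compound 3 can both go at once without a move beyond the scatter. The pair that keeps the hydroxy group isolates the fluorine: fluoro in place of methoxy on an aromatic carbon gives a 1.1-fold higher number from compound 2 to compound 4 (0.05 log units; within the scatter) and thus no readable difference either. Nothing on hand explains why these numbers stay so close.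

As far as these compounds go, what an amine or a carboxylic acid in place of the hydroxy group would do at this position stays open, as does the effect of chloro or trifluoromethyl in place of fluoro. From the compounds shown here alone, whether the closeness of these numbers would carry over to other cell types also remains open.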